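Trimming Methoxymethyl to Methoxy in a Quiet Series

This account rests on a few compounds, and the source may have more. Where it says the series, first, only, none or still open, it means among the compounds named here.

Three amides on one shared core have been tested in an ADME assay on PC-3 cells (Homo sapiens) for cytotoxicity, read by WST assay, tested at 100 uM; on this read-out higher numbers stand for more inhibition at the one concentration tested (going by the name of the read-out) and lower numbers for less inhibition. Compound 1, `O=C(Nc1ccc(Cl)cc1)C1CCCN(C(=O)c2cccc(-c3cccs3)c2)C1`, gives 4% in this assay. Compound 2, `C=Cc1cccc(C(=O)N2CCCC(C(=O)Nc3ccc(Cl)cc3)C2)c1`, gives 0%, and compound 3, `COCc1cccc(C(=O)N2CCCC(C(=O)Nc3ccc(Cl)cc3)C2)c1`, gives 0%. Compound 3 thus stands level with compound 2, the two together at the low end of the three numbers, and all three values lie within the scatter of one another, so nothing in the set so far reads as a real difference in this assay.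

Compound 4, `COc1cccc(C(=O)N2CCCC(C(=O)Nc3ccc(Cl)cc3)C2)c1`, is the next step from compound 3: methoxy in place of methoxymethyl on an aromatic carbon, the change sitting on an aromatic carbon of a six-membered aromatic ring of carbon only, meta to a large group. For the measured compounds named here, two measured steps bear on this position: a number 4 percentage points lower from compound 1 to compound 3 (within the scatter) and no change at the digits printed from compound 2 to compound 3 (within the scatter). Neither the exchange of thiophen-2-yl for methoxymethyl nor that of vinyl for methoxymethyl moved the number beyond the scatter, and the exchange of methoxymethyl for methoxy is therefore expected to leave it where it is. Accordingly the step of a number 1 percentage points higher from compound 3 to compound 4 (within the scatter) is estimated to be no step beyond the scatter, with no direction favoured. Compound 4 is expected to give about 1% in this assay, within a range from -8% to 12%.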

Compound 4, a percentage reported as inhibition, at one concentration (the size of the read-out at that concentration, not a potency): 0%
Compound 4: middle estimate off by 1 percentage points, on the high side; low and high end bracket the measured number.
By their numbers in this assay, from the lowest: compounds 2, 3, 4 and 1 (each within the scatter of the next).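

Compound 4 brings a fourth group to this aromatic carbon, and the exchange here shortens the existing group rather than replacing it with a different kind: in this assay, methoxy in place of methoxymethyl gives no change at the digits printed from compound 3 to compound 4 (within the scatter) on going from 3-(methoxymethyl)phenyl to 3-methoxyphenyl. The two further comparisons agree, with methoxy in place of vinyl giving no change at the digits printed from compound 2 to compound 4 (within the scatter) and methoxy in place of thiophen-2-yl giving a number 4 percentage points lower from compound 1 to compound 4 (within the scatter) in this series, so on the shared core these four groups are not told apart by this read-out at the one concentration tested. No supporting evidence is available to account for this lack of separation.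

The compounds shown leave open whether any group at this aromatic carbon, such as an amine, a carboxylic acid or a longer chain, can move the number beyond the scatter. They also leave open whether a change elsewhere on the shared core would do so, or whether the read-out stays this quiet across the series as a whole.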